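Adding a (phenoxymethyl)carbonyl group to compound 1

This account rests on a few compounds, and the source may have more. Where it says the series, first, only, none or still open, it means among the compounds named here.

In a functional assay on NTUB1 cells (Homo sapiens) for cytotoxicity, read by MTT assay, with a stated time of 48 h (on this read-out higher numbers stand for weaker inhibition and lower numbers for stronger inhibition), compound 1 (`C=C1CC[C@@H]2[C@](C)(CO)[C@H](O)CC[C@@]2(C)[C@@H]1CCc1ccoc1`) gives 39800 nM as its reading. Compound 2 (`C=C1CC[C@@H]2[C@](C)(COC(=O)CC)[C@H](OC(=O)CC)CC[C@@]2(C)[C@@H]1CCc1ccoc1`), an ester of the same core, gives 42900 nM as its reading, which lies within the scatter of compound 1. Compound 3 (`C=C1CC[C@@H]2[C@](C)(COC(=O)C(Cl)Cl)[C@H](OC(=O)C(Cl)Cl)CC[C@@]2(C)[C@@H]1CCc1ccoc1`), another ester of that core, gives 11300 nM as its reading, a lower number than that of compound 1 and beyond the scatter. Compound 1 therefore stands level with compound 2, and its number is higher than that of compound 3, meaning weaker inhibition.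

Compound 4 (`C=C1CC[C@@H]2[C@](C)(COC(=O)COc3ccccc3)[C@H](O)CC[C@@]2(C)[C@@H]1CCc1ccoc1`) differs from compound 1 in one place. The change is (phenoxymethyl)carbonyl in place of hydrogen on an oxygen on a saturated carbon and it puts (phenoxymethyl)carbonyl in place of hydrogen on an oxygen on a saturated carbon. Among the measured compounds shown here, no measured pair isolates this change, and the two esters point in different directions. Compound 2 at 42900 nM stays level with compound 1, while compound 3 at 11300 nM reads lower. A small move towards stronger inhibition is therefore expected, with an estimated 1.8-fold lower number from compound 1 to compound 4 (0.26 log units; within the scatter) that is not clearly beyond the scatter. For compound 4 the estimated value is 22000 nM with an expected range from 9000 nM to 45000 nM in this test.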

Compound 4, half-maximal inhibitory concentration: > 100000 nM
Compound 4 was reported as a limit; the forecaster's own chance of this, stated with the estimate: 8%; middle value at least 4.5-fold (0.65 log units) from the limit.
By their numbers in this assay, from the lowest: compound 3; then compounds 1 and 2 (each within the scatter of the next). At a limit, above all of these: compound 4.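

Compound 4 is reported only as a limit in this assay, not as a number: the limit of > 100000 nM in this assay, at which 1 of the 4 values shown sits.

Putting (phenoxymethyl)carbonyl in place of hydrogen on this oxygen gives an at least 2.5-fold higher number from compound 1 to compound 4 (0.40 log units; beyond the scatter), a move towards weaker inhibition that is beyond the scatter, and its full size stays hidden behind the limit. Compounds 2 and 3 carry ester groups on two oxygens, so neither isolates this position, whereas compound 4 differs from compound 1 at this one oxygen and shows that this single change, with the other hydroxy kept, moves the reading in the direction of weaker inhibition.

The compounds shown leave open whether this step belongs to the ester link itself or to the phenoxy part of the group that enters, a question that a plain acetyl group on the same oxygen would address. They also leave open how a group ending in an amine or a carboxylic acid, or a longer chain without the aromatic ring, would read at this position in this assay.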